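Extending the Amide Nitrogen of Compound 3

This account rests on a few compounds, and the source may have more. Where it says the series, first, only, none or still open, it means among the compounds named here.

Three analogues of one shared core have been examined in an ADME assay on SH-SY5Y cells (Homo sapiens) for cytotoxicity, read by MTT assay, with a stated time of 24 h, tested at 50 uM; a lower number here means a stronger effect, a higher number a weaker effect of the compound at the concentration tested. Compound 1 `COc1cc2c(cc1O)CCC(C)(CC(=O)N[C@@H](C)C(=O)O)O2` gives 100%, compound 2 `COc1cc2c(cc1O)CCC(C)(CC(=O)N[C@H](C(=O)O)C(C)C)O2` gives 79.3%, and compound 3 `COc1cc2c(cc1O)CCC(C)(CC(N)=O)O2` gives 99.2%. On these numbers compound 3 stands second highest of the three: its nearest neighbour is compound 1, a hair higher and within the scatter, while compound 2 lies furthest from it, a modest distance lower and beyond the scatter.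

Compound 4 `COc1cc2c(cc1O)CCC(C)(CC(=O)N[C@@H](CCC(N)=O)C(=O)O)O2` differs from compound 3 in one place: 3-carbamoyl-1-carboxypropyl in place of hydrogen on an amide-type nitrogen.

For the measured compounds named here, two measured steps bear on this change, both at the same amide-type nitrogen. Replacing 1-carboxyethyl by hydrogen gave a number 0.8 percentage points lower from compound 1 to compound 3 (within the scatter), a step within the scatter, whereas replacing 1-carboxy-2-methylpropyl by hydrogen gave a number 19.9 percentage points higher from compound 2 to compound 3 (beyond the scatter). The chain bearing isopropyl went with the lower number, and a number 20.7 percentage points lower from compound 1 to compound 2 (beyond the scatter) shows the same. Like both of those chains, the entering 3-carbamoyl-1-carboxypropyl is a 1-carboxy chain, but it lacks the isopropyl, and the data hold no step for a chain of this kind. Compound 4 is therefore expected to show a step of about a number 3.2 percentage points lower from compound 3 to compound 4 (within the scatter), not beyond the scatter. For compound 4 in this assay a value of 96% is estimated, within 80% to 105%.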

Compound 4, a percentage reported as activity, at one concentration (the size of the read-out at that concentration, not a potency): 83.2%
The estimate for compound 4 lay 12.8 percentage points above the measured number; the range from low to high includes it.
By their numbers in this assay, from the lowest: compounds 2 and 4 (each within the scatter of the next); then compounds 3 and 1 (each within the scatter of the next).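

The result shows that a chain without isopropyl can also go with a lower number at this amide-type nitrogen: in this assay, 3-carbamoyl-1-carboxypropyl in place of hydrogen gives a number 16 percentage points lower from compound 3 to compound 4 (beyond the scatter), so among the listed chains the drop is no longer confined to the one bearing isopropyl. The comparison on the saturated chain carbon places the new chain with the isopropyl chain and apart from the methyl chain, since 2-carbamoylethyl in place of isopropyl gives a number 3.9 percentage points higher from compound 2 to compound 4 (within the scatter), while carbamoylmethyl in place of hydrogen gives a number 16.8 percentage points lower from compound 1 to compound 4 (beyond the scatter), and compound 1 is the one that goes against a general drop on extending the amide nitrogen. No supporting measurement is available to explain this difference among the chains.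

As far as these compounds go, it remains open whether the lower number needs the carbamoyl at all, as a chain ending in a second carboxylic acid or in an amine could tell. From the compounds shown here alone, it also remains open how a longer chain, or a chain carrying a phenyl ring on the same saturated carbon, would stand in this assay against these values.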